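The source may hold more compounds than are shown below. What is called first, only, known or untested is meant among the compounds shown, and "the series" means these compounds.

Compound 1 `CN(C)CCn1cnnc1-c1cc(Oc2ccc(NC(=O)N/N=C/c3c(Cl)cccc3Cl)cc2F)ccn1` is the shared core bearing a 2,6-dichlorophenyl on a carbon with a double bond to nitrogen. In a functional assay on NCI-H460 cells (Homo sapiens) for cytotoxicity, read by MTT assay, with a stated time of 72 h (a higher number here means a weaker inhibitor, a lower number a stronger inhibitor), compound 1 gives 350 nM, the lowest of the three numbers. Compound 2 `CN(C)CCn1cnnc1-c1cc(Oc2ccc(NC(=O)N/N=C/c3ccccc3O[N+](=O)[O-])cc2F)ccn1` gives 1270 nM, and compound 3 `CN(C)CCn1cnnc1-c1cc(Oc2ccc(NC(=O)N/N=C/c3ccc(F)cc3)cc2F)ccn1` gives 1980 nM. Compound 4 `CN(C)CCn1cnnc1-c1cc(Oc2ccc(NC(=O)N/N=C/c3cccc(Cl)c3Cl)cc2F)ccn1` differs from compound 1 only in that part: 2,3-dichlorophenyl in place of 2,6-dichlorophenyl on a carbon with a double bond to nitrogen. Going by the values given here, two measured steps bear on this change, each also replacing the 2,6-dichlorophenyl: a 3.6-fold higher number from compound 1 to compound 2 (0.56 log units; beyond the scatter) and a 5.7-fold higher number from compound 1 to compound 3 (0.75 log units; beyond the scatter). Both moved the number higher by a modest amount. Compound 4 keeps both chlorines, so a smaller rise is expected, a 2.3-fold higher number from compound 1 to compound 4 (0.36 log units; beyond the scatter). Compound 4 is therefore estimated at 800 nM in this assay, with a range from 350 nM to 2000 nM.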

Compound 4, half-maximal inhibitory concentration: 72 nM
For compound 4 the middle estimate is 11-fold (1.05 log units) above the measured one, outside the stated range (below it).
By their numbers in this assay, from the lowest: compound 4; then compound 1; then compounds 2 and 3 (each within the scatter of the next).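

In this assay, the earlier replacements of the 2,6-dichlorophenyl on this carbon had raised the number, but rearranging the same two chlorines as 2,3-dichlorophenyl lowers it, with a 4.9-fold lower number from compound 1 to compound 4 (0.69 log units; beyond the scatter). The new group also gives a 28-fold lower number from compound 3 to compound 4 (1.44 log units; beyond the scatter) and an 18-fold lower number from compound 2 to compound 4 (1.25 log units; beyond the scatter), so carrying two chlorines does not alone fix the number among these compounds. No evidence is available to explain this gain. The compounds shown leave open whether a 2,3-dimethylphenyl or 2,3-dibromophenyl would give a similarly low number.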